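Chloro for trifluoromethyl on the urea aryl ring

This account rests on a few compounds, and the source may have more. Where it says the series, first, only, none or still open, it means among the compounds named here.

Compound 1 `O=C(Nc1cccc(-n2cc(-c3ccncc3)c(-c3cc(O)cc(Cl)c3)n2)c1)Nc1ccc(Cl)c(Cl)c1` and compound 2 `COc1cc(Cl)cc(-c2nn(-c3cccc(NC(=O)Nc4ccc(Cl)c(C(F)(F)F)c4)c3)cc2-c2ccncc2)c1` share a core and differ in the substitution of the outer urea aryl ring. In a functional assay on LOX IMVI cells (Homo sapiens) for inhibition, read by sulforhodamine B assay, with a stated time of 48 h, tested at 0.01 uM (a higher number here means a weaker effect of the compound at the concentration tested, a lower number a stronger effect), compound 1 gives 106%. In this assay compound 2 gives 98%, a number that lies within the usual scatter of that of compound 1, so the two are not distinguishable on this read-out; both leave the cells essentially unaffected at this concentration.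

Compound 3 `COc1cc(Cl)cc(-c2nn(-c3cccc(NC(=O)Nc4ccc(Cl)c(Cl)c4)c3)cc2-c2ccncc2)c1` takes one step from compound 2: chloro in place of trifluoromethyl on an aromatic carbon. Among the compounds with values here, no measured pair on record shows this particular change, so its size can only be guessed from the two numbers at hand. With compound 2 at 98% and compound 1 at 106%, both flat, the step from compound 2 to compound 3 is expected to be a number 2 percentage points higher from compound 2 to compound 3 (within the scatter), nothing beyond the scatter. Compound 3 is therefore estimated at 100%, with a range from 88% to 112%.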

Compound 3, a percentage reported as activity, at one concentration (the size of the read-out at that concentration, not a potency): 96%
For compound 3 the middle estimate is 4 percentage points above the measured one; the measured number falls inside the stated range.
By their numbers in this assay, from the lowest: compounds 3, 2 and 1 (each within the scatter of the next).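

In this assay the exchange of trifluoromethyl for chloro on the urea aryl ring gives a number 2 percentage points lower from compound 2 to compound 3 (within the scatter), so at this concentration the 4-chloro-3-(trifluoromethyl)phenyl and 3,4-dichlorophenyl groups cannot be told apart. Compound 3 also links the two earlier compounds through the oxygen on the other aromatic ring, where placing methyl on that oxygen gives a number 10 percentage points lower from compound 1 to compound 3 (within the scatter), so this change likewise leaves the read-out unresolved. Nothing on record offers an explanation for either result.

On these data alone, with all three compounds tested at a single low concentration, it remains open whether either change would separate them at a concentration where the cells respond. Also open, as far as these compounds go, is how an amine or a carboxylic acid on the urea aryl ring, or a longer chain on that oxygen, would read here.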